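Cytotoxicity read-outs across three measured compounds and one expected

The compounds below may be only part of what the source reports. "The series", "measured", "known", "first", "only" and "open" are said of these compounds alone.

Measured compounds in an ADME assay on HepG2 cells (Homo sapiens) for cytotoxicity, read by CellTiter-Glo and resazurin assay, with a stated time of 72 h; on this read-out higher numbers stand for an effect only at larger amounts of compound and lower numbers for an effect already at smaller amounts:
compound 1 `CC(C)Oc1cccc(-c2ccc(C(=O)N(Cc3cccc(OCCCCCC(=O)O)c3)C(C)C)cc2)c1` gives > 26000 nM, a limit of the assay.
compound 2 `CC(C)N(Cc1cccc(OCCCCCC(=O)O)c1)C(=O)c1ccc(-c2cccc(Oc3ccccc3)c2)cc1` gives > 18700 nM, a limit of the assay.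
compound 3 `CCOC(=O)CCCCCOc1cccc(CN(C(=O)c2ccc(-c3cccc(OC(C)C)c3)cc2)C(C)C)c1` gives > 26000 nM, a limit of the assay.

Compound 2 differs from compound 1 by phenyl in place of isopropyl on an oxygen on an aromatic ring. The step that the two limits leave unreadable from compound 1 to compound 2 is not readable; compound 1 sits at the limit of > 26000 nM in this assay, at which 2 of the 3 values shown sit, and compound 2 sits at the limit of > 18700 nM in this assay, at which 1 of the 3 values shown sits.

Compound 3 differs from compound 1 by ethyl in place of hydrogen on an oxygen next to a carbonyl group. The step that the two limits leave unreadable from compound 1 to compound 3 is likewise not readable, both compounds sitting at the limit of > 26000 nM in this assay, at which 2 of the 3 values shown sit. Compound 3 has no numeric value in this assay, only a limit, as do the other two compounds shown.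

Compound 4 `CCOC(=O)CCCCCOc1cccc(CN(C(=O)c2ccc(-c3cccc(Oc4ccccc4)c3)cc2)C(C)C)c1` differs from compound 3 by phenyl in place of isopropyl on an oxygen on an aromatic ring, the same change as from compound 1 to compound 2, made at the same place. The step that the limit leaves unreadable from compound 3 to compound 4 is expected to be small, resting on a step that the two limits leave unreadable from compound 1 to compound 2, where the same change left both values at limits. Compound 4 is expected at 30000 nM in this assay, within a range from 15000 nM to 80000 nM, and most likely again reported as a limit rather than a number.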

Compound 4, half-maximal effective concentration: > 26000 nM
Compound 4 gave a limit, no number; the forecaster's own chance of this, stated with the estimate: 85%; the middle value is on the limit's open side.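

In this assay compound 4 gives > 26000 nM, a limit and not a number. Compound 2 and compound 3 also stand only at limits, so the steps from each of them to compound 4 cannot be read. The compounds shown leave open at what concentration, if any, each of the four reaches its half-maximal effect in this assay.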